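This account rests on a few compounds, and the source may have more. Where it says the series, first, only, none or still open, it means among the compounds named here.

Working notes on the series. The shared core carries an aryl amide on one of its rings; compound 1 `CN1CCN(c2ccc(Nc3nc(-c4cccc(NC(=O)c5ccc(F)cc5)c4)sc3C(N)=O)cc2)CC1`, compound 2 `CN1CCN(c2ccc(Nc3nc(-c4cccc(NC(=O)c5cccc(F)c5)c4)sc3C(N)=O)cc2)CC1` and compound 3 `CN1CCN(c2ccc(Nc3nc(-c4cccc(NC(=O)c5ccc(Cl)cc5)c4)sc3C(N)=O)cc2)CC1` differ only in the group attached to that carbonyl carbon. In a functional assay on Raji cells (Homo sapiens) for antiproliferative activity, read by CCK-8 assay, with a stated time of 72 h (a higher number here means a weaker inhibitor, a lower number a stronger inhibitor), compound 1 gives 2820 nM. For compound 2 the result in this assay is "not determined" (no result reported), so no number is available. Going by the values given here, compound 3 gives 5700 nM in this assay, the higher of the two numbers in hand; the single measured step at this position, a 2.0-fold higher number from compound 1 to compound 3 (0.31 log units; beyond the scatter), is modest but beyond the scatter.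

Compound 4 `CN1CCN(c2ccc(Nc3nc(-c4cccc(NC(=O)c5ccc(C(F)(F)F)cn5)c4)sc3C(N)=O)cc2)CC1` is the next entry. Its change from compound 3 is 5-(trifluoromethyl)pyridin-2-yl in place of 4-chlorophenyl on a carbonyl carbon. Among the compounds with values here, the only step that touches this position, a 2.0-fold higher number from compound 1 to compound 3 (0.31 log units; beyond the scatter), exchanged one halogen for another and moved the number modestly; no measured step replaces the whole aromatic group on the carbonyl carbon, so the present change is informed only loosely. A step of similar size in either direction, or none beyond the scatter, is open. The working estimate for compound 4 in this assay is 4000 nM, with an expected range from 1500 nM to 11000 nM. The step of a 1.4-fold lower number from compound 3 to compound 4 (0.15 log units; within the scatter) is accordingly expected to be small.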

Compound 4, half-maximal inhibitory concentration: 24500 nM
For compound 4 the middle estimate is 6.1-fold (0.79 log units) below the measured one; the measured number lies above the stated range.
By their numbers in this assay, from the lowest: compound 1; then compound 3; then compound 4.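

In this assay, exchanging the whole aromatic group on the carbonyl carbon moves the number further than the halogen exchange did: the new steps are a 4.3-fold higher number from compound 3 to compound 4 (0.63 log units; beyond the scatter) and an 8.7-fold higher number from compound 1 to compound 4 (0.94 log units; beyond the scatter), against a 2.0-fold higher number from compound 1 to compound 3 (0.31 log units; beyond the scatter). The position therefore responds to more than the choice of halogen, and among the three compounds with numbers, compound 4, carrying 5-(trifluoromethyl)pyridin-2-yl, is the weakest inhibitor. This change alters the ring and its substituent together, and no supporting data are available to explain the rise in the number.

The compounds shown do not separate the two parts of the change, so a phenyl ring carrying trifluoromethyl and a pyridine ring carrying chloro would be the direct tests of which part accounts for the step. From the compounds shown here alone, whether this position tolerates anything other than a halogenated or trifluoromethyl-bearing aromatic group also stays open, for example an unsubstituted phenyl ring, or an aromatic ring carrying an amine or a carboxylic acid.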